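The source may report more compounds than this note shows. Statements on the series, on what has been measured and on what is new or still open speak of the compounds shown alone.

Measured compounds in a functional assay on SK-BR-3 cells (Homo sapiens) for antiproliferative activity, read by MTT assay, with a stated time of 72 h; a lower number here means a stronger inhibitor, a higher number a weaker inhibitor:
compound 1 `CCN1CCN(c2cc(C)c3cc(NC(=O)c4cccnc4)ccc3n2)CC1` gives 10600 nM
compound 2 `CCN1CCN(c2cc(C)c3cc(NC(=O)c4cccc(C)c4)ccc3n2)CC1` gives 13700 nM
compound 3 `CCN1CCN(c2cc(C)c3cc(NC(=O)c4ccc(Br)cc4)ccc3n2)CC1` gives 6310 nM

Compound 3 has the lowest number of the three; its gap to compound 1 lies within the scatter, while a 2.2-fold lower number from compound 2 to compound 3 (0.34 log units; beyond the scatter) is a modest step beyond it. Compound 4 `CCN1CCN(c2cc(C)c3cc(NC(=O)c4ccccc4Br)ccc3n2)CC1` differs from compound 3 in one place: 2-bromophenyl in place of 4-bromophenyl on a carbonyl carbon. Among the compounds with values here, none of the measured steps moves a bromine around the ring; the steps that vary the aryl group, a 1.3-fold higher number from compound 1 to compound 2 (0.11 log units; within the scatter) and a 1.7-fold lower number from compound 1 to compound 3 (0.23 log units; within the scatter), are small, so a small change or none beyond the scatter is expected here. Compound 4 is therefore estimated at 9000 nM in this assay, with a range of 3500 nM to 25000 nM, which means an expected step of a 1.4-fold higher number from compound 3 to compound 4 (0.15 log units; within the scatter).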

Compound 4, half-maximal inhibitory concentration: 39200 nM
For compound 4 the middle estimate is 4.4-fold (0.64 log units) below the measured one; the whole stated range lies below it.
By their numbers in this assay, from the lowest: compounds 3, 1 and 2 (each within the scatter of the next, the first and the last beyond it); then compound 4.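

Moving the bromine, from 4-bromophenyl to 2-bromophenyl on the same carbonyl carbon, gives in this assay a 6.2-fold higher number from compound 3 to compound 4 (0.79 log units; beyond the scatter) and exceeds every step among the earlier compounds, so at this position the place of the bromine counts for more than the aryl changes seen before. Compound 4 also separates from the others, with a 2.9-fold higher number from compound 2 to compound 4 (0.46 log units; beyond the scatter) and a 3.7-fold higher number from compound 1 to compound 4 (0.57 log units; beyond the scatter) beyond what the earlier aryl groups showed among themselves. Nothing available explains this shift.

Going by these compounds, whether a chlorine or a methoxy group in place of the bromine of compound 4 would give the same weakening remains open.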